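Aryl substituent variation on the pyridinone-free shared core

The source may hold more compounds than are shown below. What is called first, only, known or untested is meant among the compounds shown, and "the series" means these compounds.

Compound 1 `CCOC(=O)c1c(C)[nH]c(=O)c(C#N)c1-c1ccc(C)cc1` and compound 2 `CCOC(=O)c1c(C)[nH]c(=O)c(C#N)c1-c1ccc(Br)cc1` share one core and differ only in the aryl group. In a functional assay on HepG2 cells (Homo sapiens) for inhibition, read by MTT assay, with a stated time of 24 h (a higher number here means a weaker inhibitor, a lower number a stronger inhibitor), compound 1 gives 11900 nM, and in this assay compound 2 gives 65500 nM. Among the compounds with values here, the only measured step, a 5.5-fold higher number from compound 1 to compound 2 (0.74 log units; beyond the scatter), makes compound 2 the higher of the two numbers.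

Compound 3 `CCOC(=O)c1c(C)[nH]c(=O)c(C#N)c1-c1ccccc1Cl` carries 2-chlorophenyl in place of 4-bromophenyl on an aromatic carbon. Within the data shown here, no measured step exchanges one halogen for another or moves a substituent around the ring, so the step from compound 1 to compound 2 bears on it only loosely: it shows that a halogen on this aryl group can lift the number well beyond the scatter. Since compound 3 keeps a halogen but changes both its kind and its place, a number between those of compound 1 and compound 2 is expected, with wide uncertainty. Compound 3 is therefore estimated at 30000 nM (range 8000 nM to 120000 nM), an expected step of a 2.2-fold lower number from compound 2 to compound 3 (0.34 log units; beyond the scatter).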

Compound 3, half-maximal inhibitory concentration: 34100 nM
For compound 3 the middle estimate is 1.1-fold (0.06 log units) below the measured one; measured number inside the range.
By their numbers in this assay, from the lowest: compound 1; then compounds 3 and 2 (each within the scatter of the next).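

Exchanging 4-bromophenyl for 2-chlorophenyl on this aromatic carbon of the shared core gives a 1.9-fold lower number from compound 2 to compound 3 (0.28 log units; within the scatter) and so does not separate the two halogen-bearing aryl groups in this assay, even though the halogen and its place on the aryl group both differ. Exchanging 4-methylphenyl for 2-chlorophenyl gives a 2.9-fold higher number from compound 1 to compound 3 (0.46 log units; beyond the scatter) and so, among these three compounds, both halogen-bearing aryl groups stand apart from the methyl-bearing one. No measurement is available that accounts for these numbers.

The kind of halogen and its place change together in this pair, so neither can be read on its own. On these data alone, how an unsubstituted phenyl group, or an aryl group carrying an amine or a carboxylic acid, would behave at this position remains open.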